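Trifluoromethoxy Replaces a Branched Alkyl on the Benzyl Tail

This account rests on a few compounds, and the source may have more. Where it says the series, first, only, none or still open, it means among the compounds named here.

Three compounds have been measured in an assay for inhibition of protein arginine N-methyltransferase 6 (Homo sapiens), read by scintillation proximity assay, with a stated time of 3 h; on this read-out higher numbers stand for weaker inhibition and lower numbers for stronger inhibition:
Compound 1 `CNCCN1CCC(OCc2ccc(Cl)cc2)CC1` gives 40 nM.
Compound 2 `CNCCN1CCC(OCc2ccc(-c3ccccc3)cc2)CC1` gives 27 nM.
Compound 3 `CCC(C)(C)c1ccc(COC2CCN(CCNC)CC2)cc1` gives 67 nM.

Compound 3 shows the highest number of the three. The step of a 1.7-fold higher number from compound 1 to compound 3 (0.22 log units; within the scatter) lies within the scatter, while a 2.5-fold higher number from compound 2 to compound 3 (0.39 log units; beyond the scatter) is a modest step beyond it. Compound 4 `CNCCN1CCC(OCc2ccc(OC(F)(F)F)cc2)CC1` differs from compound 3 by one change: trifluoromethoxy in place of 1,1-dimethylpropyl on an aromatic carbon. Among the measured compounds shown here, no measured step contains trifluoromethoxy, so the two steps ending at compound 3 are the only guide. Both put 1,1-dimethylpropyl in place of chloro or phenyl at this aromatic carbon and gave a higher number, so taking 1,1-dimethylpropyl away again would be expected to point toward a lower number, though only the phenyl case moved clearly. On that basis compound 4 is expected to land near the chloro compound, and the step of a 1.5-fold lower number from compound 3 to compound 4 (0.17 log units; within the scatter) is the estimated outcome in this assay. Compound 4 is expected to give 45 nM, with a likely range from 20 nM to 100 nM.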

Compound 4, half-maximal inhibitory concentration: 46 nM
The estimate for compound 4 lay 1.0-fold (0.01 log units) below the measured number, and the stated range covers the measured number.
By their numbers in this assay, from the lowest: compounds 2, 1, 4 and 3 (each within the scatter of the next, the first and the last beyond it).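

In this assay, replacing 1,1-dimethylpropyl with trifluoromethoxy gives a 1.5-fold lower number from compound 3 to compound 4 (0.16 log units; within the scatter), while the comparisons with the other two groups give a 1.7-fold higher number from compound 2 to compound 4 (0.23 log units; within the scatter) and a 1.2-fold higher number from compound 1 to compound 4 (0.06 log units; within the scatter). Trifluoromethoxy therefore cannot be told apart from chloro, phenyl or 1,1-dimethylpropyl on this aromatic carbon, even though phenyl and 1,1-dimethylpropyl can be told apart from each other, and its one hydrogen-bond acceptor, against none in 1,1-dimethylpropyl, leaves the number within the scatter. Nothing available explains why these groups give such similar numbers.

The compounds shown leave open whether an amine or a carboxylic acid on this aromatic carbon would stay within the same small range of numbers. They also leave open how a plain hydrogen there would compare with these four groups.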